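Trifluoromethyl in place of piperidin-1-yl: an expected potency step

The compounds below may be only part of what the source reports. "The series", "measured", "known", "first", "only" and "open" are said of these compounds alone.

Of the compounds shown here, three sharing one core have been tested in a functional assay for inhibition of sodium/hydrogen exchanger (Oryctolagus cuniculus); a lower number here means a stronger inhibitor, a higher number a weaker inhibitor. Compound 1 `CCCc1cc(C)c(C(=O)N=C(N)N)cc1S(C)(=O)=O` gives 5.7 nM, compound 2 `Cc1cc(-c2cc(Cl)cc(Cl)c2)c(S(C)(=O)=O)cc1C(=O)N=C(N)N` gives 130 nM, and compound 3 `Cc1cc(N2CCCCC2)c(S(C)(=O)=O)cc1C(=O)N=C(N)N` gives 21 nM. Compound 3 thus holds the second highest of the three numbers: the step of a 3.7-fold higher number from compound 1 to compound 3 (0.57 log units; beyond the scatter) was modest, the step of a 6.2-fold lower number from compound 2 to compound 3 (0.79 log units; beyond the scatter) was modest in the other direction, and the largest measured step was a 23-fold higher number from compound 1 to compound 2 (1.36 log units; beyond the scatter).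

Compound 4 `Cc1cc(C(F)(F)F)c(S(C)(=O)=O)cc1C(=O)N=C(N)N` has not been measured. It differs from compound 3 in one place: trifluoromethyl in place of piperidin-1-yl on an aromatic carbon. Among the measured compounds shown here, the step that bears most on this change is a 3.7-fold higher number from compound 1 to compound 3 (0.57 log units; beyond the scatter), the only one that exchanges piperidin-1-yl for a group as small as the entering trifluoromethyl; the large step of a 23-fold higher number from compound 1 to compound 2 (1.36 log units; beyond the scatter) shows that the highest number comes with a 3,5-dichlorophenyl group, not with a small substituent. Compound 4 is therefore expected to show a 2.1-fold lower number from compound 3 to compound 4 (0.32 log units; beyond the scatter). Compound 4 is estimated to give 10 nM in this assay, within a range of 3 nM to 35 nM.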

Compound 4, half-maximal inhibitory concentration: 37 nM
Compound 4: the middle estimate sits 3.7-fold (0.57 log units) below what was measured, outside the stated range (above it).
By their numbers in this assay, from the lowest: compound 1; then compounds 3 and 4 (each within the scatter of the next); then compound 2.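

In this assay the exchange of piperidin-1-yl for trifluoromethyl gives a 1.8-fold higher number from compound 3 to compound 4 (0.25 log units; within the scatter) so at this position, ortho to a methylsulfonyl group, a group with no ring and a six-membered ring holding one nitrogen cannot be told apart. Trifluoromethyl does not match propyl here: the change from propyl gives a 6.5-fold higher number from compound 1 to compound 4 (0.81 log units; beyond the scatter) and the change from 3,5-dichlorophenyl gives a 3.5-fold lower number from compound 2 to compound 4 (0.55 log units; beyond the scatter) so compound 1 remains the most potent of the four and compound 2 the least. Nothing measured on these compounds accounts for these gaps.

As far as these compounds go, whether the advantage of propyl belongs to an open carbon chain in general remains open, and ethyl or butyl would test that. From the compounds shown here alone, it is also open whether an open-chain amine such as dimethylamino would stay level with piperidin-1-yl.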